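From 4-ethylphenyl to 3-chloro-4-fluorophenyl on a sulfonamide nitrogen

The source may hold more compounds than are shown below. What is called first, only, known or untested is meant among the compounds shown, and "the series" means these compounds.

Measured in a functional assay on Huh-7 cells (Homo sapiens) for inhibition, read by CCK-8 assay, with a stated time of 72 h; a lower number here means a stronger inhibitor, a higher number a weaker inhibitor:
- compound 1 `Cc1ccc(NS(=O)(=O)c2cccc(CCCCCCNC(=O)/C=C/c3cccnc3)c2)cc1` gives 6.92 nM
- compound 2 `Cc1cccc(NS(=O)(=O)c2cccc(CCCCCCNC(=O)/C=C/c3cccnc3)c2)c1` gives 13.2 nM
- compound 3 `CCc1ccc(NS(=O)(=O)c2cccc(CCCCCCNC(=O)/C=C/c3cccnc3)c2)cc1` gives 34.6 nM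

Compound 3 has the highest number of the three, reached by a 5.0-fold higher number from compound 1 to compound 3 (0.70 log units; beyond the scatter) and by a 2.6-fold higher number from compound 2 to compound 3 (0.42 log units; beyond the scatter). The remaining step is a 1.9-fold higher number from compound 1 to compound 2 (0.28 log units; within the scatter). Compound 4 `O=C(/C=C/c1cccnc1)NCCCCCCc1cccc(S(=O)(=O)Nc2ccc(F)c(Cl)c2)c1` differs from compound 3 thus: 3-chloro-4-fluorophenyl in place of 4-ethylphenyl on a sulfonamide nitrogen. That is 3-chloro-4-fluorophenyl in place of 4-ethylphenyl on a sulfonamide nitrogen. For the measured compounds named here, no measured compound carries chlorine or fluorine, so the steps guide only loosely. Both steps into compound 3 raise the number, so leaving 4-ethylphenyl is expected to lower it in this assay, by a similar or smaller size. The expected step is a 2.5-fold lower number from compound 3 to compound 4 (0.39 log units; beyond the scatter). Compound 4 is estimated at 14 nM, with a range from 4 nM to 45 nM.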

Compound 4, half-maximal inhibitory concentration: 39.4 nM
Compound 4: middle estimate off by 2.8-fold (0.45 log units), on the low side; low and high end bracket the measured number.
By their numbers in this assay, from the lowest: compounds 1 and 2 (each within the scatter of the next); then compounds 3 and 4 (each within the scatter of the next).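

In this assay the step to 3-chloro-4-fluorophenyl on the sulfonamide nitrogen gives a 1.1-fold higher number from compound 3 to compound 4 (0.06 log units; within the scatter) and so leaves this position where 4-ethylphenyl had it, while the two methylphenyl groups keep the lower numbers, with a 3.0-fold higher number from compound 2 to compound 4 (0.47 log units; beyond the scatter) and a 5.7-fold higher number from compound 1 to compound 4 (0.76 log units; beyond the scatter). Chlorine and fluorine together on this ring therefore bring no gain over either methylphenyl group in this set of four. Nothing available explains this result.

From the compounds shown here alone, whether chlorine or fluorine alone would behave the same stays open. So does the effect of a methoxy or an amine on this ring.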